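The source may hold more compounds than are shown below. What is called first, only, known or untested is meant among the compounds shown, and "the series" means these compounds.

Three compounds have been measured in a functional assay on CCRF-CEM cells (Homo sapiens) for inhibition, read by sulforhodamine B assay, with a stated time of 48 h, tested at 10 uM; on this read-out higher numbers stand for more inhibition at the one concentration tested (going by the name of the read-out) and lower numbers for less inhibition:
compound 1 `O=Cc1ccc(-c2cn3ccnc3c(-c3ccc4ncn(C5CCCCC5)c4c3)n2)cc1` gives 77.9%;
compound 2 `O=Cc1ccc(-c2cn3ccnc3c(-c3ccc4ncn(Cc5ccccc5)c4c3)n2)cc1` gives 77.9%;
compound 3 `c1cn2cc(-c3ccc4c(c3)ncn4C3CCCCC3)nc(-c3ccc4ncn(C5CCCCC5)c4c3)c2n1` gives 46.1%.

Compound 1 and compound 2 share a core and differ by benzyl in place of cyclohexyl on an aromatic nitrogen; this change made the step of no change at the digits printed from compound 1 to compound 2 (within the scatter) in this assay. Compound 3 is built on another core, and how the two cores differ is not broken down here. Compound 3 stands lowest of the three numbers, with compound 1 and compound 2 both beyond the scatter above it.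

Compound 4 `c1ccc(Cn2cnc3ccc(-c4nc(-c5ccc6c(c5)ncn6C5CCCCC5)cn5ccnc45)cc32)cc1` has not yet been measured. It differs from compound 3 by benzyl in place of cyclohexyl on an aromatic nitrogen, the same change that separates compound 1 from compound 2, at the same place. Since that change made no change at the digits printed from compound 1 to compound 2 (within the scatter) on the core of compound 1, the step from compound 3 to compound 4 is expected to be about as small, a number 0.1 percentage points lower from compound 3 to compound 4 (within the scatter). This rests on a single measured pair, so the expectation is held loosely. Compound 4 is therefore estimated at 46% in this assay, with a likely range from 30% to 62%.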

Compound 4, a percentage reported as inhibition, at one concentration (the size of the read-out at that concentration, not a potency): 94.4%
Compound 4: middle estimate off by 48.4 percentage points, on the low side; measured number above the stated range.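

In this assay, benzyl in place of cyclohexyl on an aromatic nitrogen gave a number 48.3 percentage points higher from compound 3 to compound 4 (beyond the scatter), so the change did not carry over at the same size from one core to the other: the same change on two cores in this assay, no change at the digits printed (within the scatter) from compound 1 to compound 2 and a number 48.3 percentage points higher (beyond the scatter) from compound 3 to compound 4, 48.3 percentage points apart, beyond the scatter of two such steps The step that was silent on the core of compound 1 therefore cannot be taken as a guide to the same change on the core of compound 3. For the compounds shown here, these two pairs do not show why the steps differ, and with only two cores, read at a single concentration, they give no rule for what the change would do on a third core.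

The compounds shown leave open whether a group other than benzyl on that aromatic nitrogen, such as a longer chain ending in a phenyl ring or an amine, would follow compound 4 or compound 3. They also leave open what benzyl would do in place of the cyclohexyl that remains in compound 4.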